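Swapping a Difluorophenyl for a Trimethylphenyl Sulfonamide

A few compounds are considered here, and "the series" means these few. Any claim that something is new, unique, unknown or untested is made for them only; others in the source may bear on it.

Measured so far:
- compound 1, `N#Cc1ccc(Nc2cc(NS(=O)(=O)c3cc(F)cc(F)c3)ccn2)cc1`: 28600 nM
- compound 2, `Cc1cc(C)c(S(=O)(=O)Nc2ccnc(Nc3ccc(C#N)cc3)c2)c(C)c1`: 22200 nM
- compound 3, `N#Cc1ccc(Nc2nccc(NS(=O)(=O)c3cc(F)cc(F)c3)n2)cc1`: 93900 nM

These three compounds were tested in an ADME assay on MT4 cells (Homo sapiens) for cytotoxicity, read by MTT assay, with a stated time of 5 days; a higher number here means that more compound is tolerated, a lower number that less compound is tolerated. Compound 1 and compound 2 share one core and differ only in the group on the sulfonyl sulfur: 2,4,6-trimethylphenyl in place of 3,5-difluorophenyl on a sulfonyl sulfur. The step of a 1.3-fold lower number from compound 1 to compound 2 (0.11 log units; within the scatter) is small. Compound 3 carries a different core; how the two cores differ is not broken down here. In this assay compound 3 gives the highest of the three values, beyond the scatter from both of the others.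

Compound 4, `Cc1cc(C)c(S(=O)(=O)Nc2ccnc(Nc3ccc(C#N)cc3)n2)c(C)c1`, is not yet measured. It is related to compound 3 by the same change that relates compound 2 to compound 1: 2,4,6-trimethylphenyl in place of 3,5-difluorophenyl on a sulfonyl sulfur. Since the earlier step of a 1.3-fold lower number from compound 1 to compound 2 (0.11 log units; within the scatter) stayed within the scatter, the expected step for compound 4 is similar, a 1.3-fold lower number from compound 3 to compound 4 (0.10 log units; within the scatter), resting on that single prior case. For compound 4 the estimate in this assay is 75000 nM, with a likely range from 35000 nM to 160000 nM.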

Compound 4, half-maximal cytotoxic concentration: 4400 nM
Beside the measured number, compound 4's estimate is 17-fold (1.23 log units) above it; measured number outside the range, below it.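

In this assay, placing 2,4,6-trimethylphenyl instead of 3,5-difluorophenyl on the sulfonyl sulfur gives a large step, a 21-fold lower number from compound 3 to compound 4 (1.33 log units; beyond the scatter). The effect of this change therefore did not carry over in size from one core to the other, and the core it is made on matters in this small set: the same change on two cores in this assay, a 1.3-fold lower number (0.11 log units; within the scatter) from compound 1 to compound 2 and a 21-fold lower number (1.33 log units; beyond the scatter) from compound 3 to compound 4, 17-fold (1.22 log units) apart, beyond the scatter of two such steps

Going by these compounds alone, this rests on only two matched pairs, so it does not show which difference between the cores is responsible, nor which of the two steps would be more typical of other cores.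

The compounds shown leave open how other groups on the sulfonyl sulfur, such as an unsubstituted phenyl, a methyl or a dimethylamino group, would behave on these two cores, and whether the gap between the steps would persist. They also leave open whether it would survive replacing the nitrile with a carboxylic acid.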